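This account rests on a few compounds, and the source may have more. Where it says the series, first, only, none or still open, it means among the compounds named here.

Compound 3 `Cc1cccc(Nc2nc(N)nc(COc3ccc4c(C)cc(=O)oc4c3)n2)c1` gives 1780 nM in an assay on COS-7 cells for agonist activity at Free fatty acid receptor 1 (Homo sapiens), read by scintillation counting and inositol phosphate accumulation, with a stated time of 90 min; on this read-out higher numbers stand for an effect only at larger amounts of compound and lower numbers for an effect already at smaller amounts; compound 2 `Cc1ccc(Nc2nc(N)nc(COc3ccc4c(C)cc(=O)oc4c3)n2)cc1` gives 1790 nM, and the two sit together at the low end of the three numbers, while compound 1 `Cc1cc(=O)oc2cc(OCc3nc(N)nc(Nc4ccc(F)cc4)n3)ccc12` gives 18300 nM. Compound 4 `Cc1cc(=O)oc2cc(OCc3nc(N)nc(Nc4cccc(Cl)c4)n3)ccc12` differs from compound 3 by chloro in place of methyl on an aromatic carbon. Within the data shown here, no measured step exchanges methyl for chloro directly. The steps of a 10-fold lower number from compound 1 to compound 2 (1.01 log units; beyond the scatter) and a 10-fold lower number from compound 1 to compound 3 (1.01 log units; beyond the scatter) both run from a fluoro-bearing ring to a methyl-bearing one, and a 1.0-fold lower number from compound 2 to compound 3 (0.00 log units; within the scatter) shows the two methyl placements within the scatter. Chloro is a halogen but not fluoro, so the evidence is thin; a moderate rise in this assay is expected, a 2.0-fold higher number from compound 3 to compound 4 (0.29 log units; within the scatter). Compound 4 is estimated at 3500 nM, with a range from 1000 nM to 12000 nM.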

Compound 4, half-maximal effective concentration: 1110 nM
Compound 4: the middle estimate sits 3.2-fold (0.50 log units) above what was measured; the range from low to high includes it.
By their numbers in this assay, from the lowest: compounds 4, 3 and 2 (each within the scatter of the next); then compound 1.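

In this assay, chloro can take the place of methyl on this aromatic carbon with no change beyond the scatter: a 1.6-fold lower number from compound 3 to compound 4 (0.21 log units; within the scatter). The 3-chlorophenyl compound also stays within the scatter of the 4-methylphenyl compound, a 1.6-fold lower number from compound 2 to compound 4 (0.21 log units; within the scatter), while a 16-fold lower number from compound 1 to compound 4 (1.22 log units; beyond the scatter) leaves the 4-fluorophenyl compound alone, apart from the other three. No measurement shown here accounts for these results.

Open, going by these compounds, is whether the gap to compound 1 follows the fluoro group or its place on the ring, a question a 3-fluorophenyl group would address. Also open, on these data alone, is how a methoxy or an amine group would fare at this position.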